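The compounds below may be only part of what the source reports. "The series", "measured", "known", "first", "only" and "open" are said of these compounds alone.

Measured compounds:
Compound 1 `COC(=O)c1cc(O)ccc1OC(=O)COc1cc(O)c2c(=O)cc(-c3ccccc3)oc2c1` gives 29500 nM in a functional assay on cells (T-cell, Mus musculus, strain BALB/c) for inhibition, read by MTT assay, with a stated time of 72 h; a lower number here means a stronger inhibitor, a higher number a weaker inhibitor.
Compound 2 `COC(=O)c1cccc(C)c1OC(=O)COc1cc(O)c2c(=O)cc(-c3ccccc3)oc2c1` gives 39100 nM in this assay.
Compound 3 `COC(=O)c1c(Br)cccc1OC(=O)COc1cc(O)c2c(=O)cc(-c3ccccc3)oc2c1` gives 41700 nM in this assay.

Compound 1 has the lowest of the three numbers, but the steps to the other two, a 1.3-fold higher number from compound 1 to compound 2 (0.12 log units; within the scatter) and a 1.4-fold higher number from compound 1 to compound 3 (0.15 log units; within the scatter), both lie within the scatter, so the three compounds cannot be ranked against one another on these data.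

Compound 4 `COC(=O)c1ccc(Br)cc1OC(=O)COc1cc(O)c2c(=O)cc(-c3ccccc3)oc2c1` has not yet been measured. Relative to compound 1 the change is a group of 11 heavy atoms (8 carbon, 2 oxygen, 1 bromine; one six-membered aromatic ring of carbon only) in place of a group of 11 heavy atoms (8 carbon, 3 oxygen; one six-membered aromatic ring of carbon only), on an oxygen next to a carbonyl group.

Both measured steps from compound 1 exchange a group of 11 heavy atoms at the same place, on an oxygen next to a carbonyl group, and neither moved the number beyond the scatter. Compound 3 already carries a bromine in its entering group, and a 1.1-fold higher number from compound 2 to compound 3 (0.03 log units; within the scatter) is flat as well. The exchange in compound 4 is of the same kind, so no step beyond the scatter is expected in this assay in either direction.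

Compound 4 is therefore estimated at 37000 nM, with a range of 18000 nM to 75000 nM. This estimate means a step of a 1.3-fold higher number from compound 1 to compound 4 (0.10 log units; within the scatter).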

Compound 4, half-maximal inhibitory concentration: 17600 nM
Estimate against measurement, compound 4: 2.1-fold (0.32 log units) above, outside the stated range (below it).
By their numbers in this assay, from the lowest: compounds 4, 1, 2 and 3 (each within the scatter of the next, the first and the last beyond it).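

This position does respond in this assay and a 2.4-fold lower number from compound 3 to compound 4 (0.37 log units; beyond the scatter) lies beyond the scatter, although the entering groups have the same atom counts and differ only in where the bromine sits on the ring. The presence of a bromine in the group therefore does not set the number by itself. The series also gives a 2.2-fold lower number from compound 2 to compound 4 (0.35 log units; beyond the scatter) and a 1.7-fold lower number from compound 1 to compound 4 (0.22 log units; within the scatter) as steps, the first beyond the scatter and the second within it, so compound 4 separates from compound 2 and compound 3 but not from compound 1. No measurement on hand bears on the cause of these steps.

Still open, from the compounds shown here alone, is whether an amine or a carboxylic acid in place of the bromine would move the number further than these modest steps. A chlorine at the place of the bromine in compound 4 would show whether this result is specific to bromine.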